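The source may hold more compounds than are shown below. What is called first, only, known or untested is meant among the compounds shown, and "the series" means these compounds.

Compound 1 `O=C1C2=C(C(=O)c3ncccc31)C1(CS2)NC(=O)N(c2ccc(Cl)cc2)C1=O` holds the lowest number of the two compounds measured in a functional assay on XF498 cells (Homo sapiens) for antiproliferative activity, read by MTT assay, with a stated time of 96 h (on this read-out higher numbers stand for weaker inhibition and lower numbers for stronger inhibition), where compound 1 gives 590 nM. Within the data shown here, the only other measured compound, compound 2 `O=C1NN(c2ccc(Cl)cc2)C(=O)C2(CSC3=C2C(=O)c2ncccc2C3=O)N1`, gives 2500 nM in this assay, a higher number that lies beyond the usual scatter, so compound 1 is the stronger of the two.

Compound 3 `CC(C)(C)c1ccc(N2C(=O)NC3(CSC4=C3C(=O)c3ncccc3C4=O)C2=O)cc1` has not yet been measured. It differs from compound 1 in one place: tert-butyl in place of chloro on an aromatic carbon. Among the measured compounds shown here, no pair of measured compounds differs in exactly this way, so nothing in the measured numbers shows what such a change does to the read-out in this assay.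

With no guide from a measured step, the expectation for compound 3 is a small step from compound 1, a 1.5-fold higher number from compound 1 to compound 3 (0.18 log units; within the scatter), toward a somewhat higher number, near the edge of the scatter. Compound 3 is therefore estimated at 900 nM, within a range of 300 nM to 2700 nM.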

Compound 3, half-maximal inhibitory concentration: 850 nM
Compound 3: the middle estimate sits 1.1-fold (0.02 log units) above what was measured; low and high end bracket the measured number.
By their numbers in this assay, from the lowest: compounds 1 and 3 (each within the scatter of the next); then compound 2.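

In this assay, tert-butyl, with 4 heavy atoms, takes the place of chloro, with 1 heavy atom, on the aromatic carbon para to a large group, and this exchange gives a 1.4-fold higher number from compound 1 to compound 3 (0.16 log units; within the scatter) on the core of compound 1. The 4-chlorophenyl and 4-(tert-butyl)phenyl forms therefore stand level, so this position accepts either group without a step beyond the scatter. Nothing measured here explains why the two read alike.

Going by these compounds, whether an amine, a carboxylic acid or a methoxy group on the same aromatic carbon would also stay level with compound 1 remains open. On these data alone, it is also open whether tert-butyl in place of chloro would give a similar step on compound 2, whose core differs.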